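This account rests on a few compounds, and the source may have more. Where it says the series, first, only, none or still open, it means among the compounds named here.

Measured compounds:
- Compound 1 `CCc1ccc2nc(C(=O)Nc3c(F)cc(-c4cccc(F)c4)cc3F)c(C)c(O)c2c1` in a functional assay on A-375 cells (Homo sapiens) for antiproliferative activity, read by MTT assay, with a stated time of 24 h, tested at 3.7 ug/mL (on this read-out higher numbers stand for a stronger effect at the one concentration tested and lower numbers for a weaker effect), gives 17.9%
- Compound 2 `Cc1c(C(=O)Nc2c(F)cc(-c3cccc(F)c3)cc2F)nc2ccc(F)cc2c1O` in this assay gives 7.85%

Going by the values given here, of the two numbers, compound 2 stands lowest: the only step known, a number 10.1 percentage points lower from compound 1 to compound 2 (beyond the scatter), shows the drop that came with a single swap of groups at one aromatic carbon. Compound 3 `CCOc1ccc2nc(C(=O)Nc3c(F)cc(-c4cccc(F)c4)cc3F)c(C)c(O)c2c1` is the next, still unmeasured, compound. It differs from compound 2 at that same carbon, where (ethoxy in place of fluoro on an aromatic carbon). Among the compounds with values here, the one measured step bears directly on this: it joined the ethyl-bearing compound 1 to the fluoro-bearing compound 2 and was modest in size. Replacing the fluoro in turn with an ethoxy group is expected to move the number back in the direction of compound 1, by about a number 7.2 percentage points higher from compound 2 to compound 3 (within the scatter). In this assay compound 3 is therefore estimated at 15%, with a range from 5% to 28%.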

Compound 3, a percentage reported as inhibition, at one concentration (the size of the read-out at that concentration, not a potency): 4.56%
For compound 3 the middle estimate is 10.4 percentage points above the measured one; measured number below the stated range.
By their numbers in this assay, from the lowest: compounds 3 and 2 (each within the scatter of the next); then compound 1.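

In this assay, swapping the fluoro group for the ethoxy group at this carbon gives a number 3.3 percentage points lower from compound 2 to compound 3 (within the scatter), so these two groups cannot be told apart here. Putting ethoxy in place of ethyl gives a number 13.3 percentage points lower from compound 1 to compound 3 (beyond the scatter), and this step, together with the earlier fluoro step, sets compound 1 apart from the other two. Among the three groups tried at this carbon, the higher number therefore belongs to ethyl alone, and an added oxygen in the ethoxy group does not preserve it, even though ethoxy is also a chain. Nothing available explains these differences. Still open, as far as these compounds go, is whether the higher number is particular to ethyl, or whether a longer chain such as propyl, or an amine at this carbon, would also give it.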